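A few compounds are considered here, and "the series" means these few. Any claim that something is new, unique, unknown or untested is made for them only; others in the source may bear on it.

Measured compounds:
compound 1 `CC(=O)Nc1cc(-c2ccc(OC[C@@H](N)CC(C)C)c(Cl)c2)ccn1`, 0.5 nM
compound 2 `COC(=O)Nc1cc(-c2cnc(OC[C@@](C)(N)CC(C)C)c(C#N)c2)ccn1`, 1 nM

Both were tested in an assay on isolated protein for inhibition of AP2-associated protein kinase 1 (Homo sapiens), with a stated time of 3 h, in the presence of a further agent that is not named here; a lower number here means a stronger inhibitor, a higher number a weaker inhibitor. Compound 1 gives 0.5 nM, the lowest of the two numbers. Compound 2 gives 1 nM, and the gap to compound 1 lies within the usual scatter, so the two cannot be ordered against each other. Within the data shown here, no pair of measured compounds differs in a single place, so the data hold no step of known size on which to lean.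

Compound 3 `CC(=O)Nc1cc(-c2ccc(OC[C@@H](N)CC(C)C)cc2)ccn1` is not yet measured. It differs from compound 1 by hydrogen in place of chloro on an aromatic carbon, in words: hydrogen in place of chloro on an aromatic carbon. Among the measured compounds shown here, since no comparable step is available, the expectation rests on compound 1 and its value of 0.5 nM as the starting point. A small rise of the number is expected, close to the edge of the scatter, with the step estimated as a 3.0-fold higher number from compound 1 to compound 3 (0.48 log units; beyond the scatter). For compound 3 the expected result in this assay is 1.5 nM, with a range from 0.5 nM to 5 nM.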

Compound 3, half-maximal inhibitory concentration: 4.6 nM
Beside the measured number, compound 3's estimate is 3.1-fold (0.49 log units) below it, within the range that was stated.
By their numbers in this assay, from the lowest: compounds 1 and 2 (each within the scatter of the next); then compound 3.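

In this assay, hydrogen in place of chloro on the aromatic carbon ortho to the (2-amino-4-methylpentyl)oxy group gives a 9.2-fold higher number from compound 1 to compound 3 (0.96 log units; beyond the scatter), so the chloro of compound 1 contributes measurably to its low number in this series. Among these compounds, this is the first step between compounds that differ in one place, and it gives this position a measured size that the earlier pair of compounds could not provide, with the loss of the chlorine as the only structural change. Nothing at hand bears on the origin of this step, which therefore stands as an observation on this one pair of compounds.

On these data alone, whether a fluoro, bromo or methyl group at this position would keep the number close to that of compound 1 at 0.5 nM, or would track with the hydrogen of compound 3 instead, remains open. Also open, as far as these compounds go, is whether the step keeps its size on other versions of the core, since compound 2 differs from compound 1 in more than one place and gives no separate reading of this position.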